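Methyl for Chloro: Stability in Rat Liver Microsomes

The compounds below may be only part of what the source reports. "The series", "measured", "known", "first", "only" and "open" are said of these compounds alone.

Measured in an ADME assay on microsomes from liver (Rattus norvegicus) for metabolic stability, read by LC-MS, with a stated time of 30 min, tested at 1 uM; a higher number here means that more of the compound is left, a lower number that less of the compound is left:
compound 1, `CC(C)(C)NCc1cc(Cl)cc(Nc2nc3cc(F)c(F)cc3n2Cc2ccc(C(F)(F)F)cc2)c1O`, 94%
compound 2, `CCNCc1cc(C)cc(Nc2nc3ccccc3n2Cc2ccc(C(F)(F)F)cc2)c1O`, 51%
compound 3, `CCNCc1cc(Cl)cc(Nc2nc3ccccc3n2Cc2ccc(C(F)(F)F)cc2)c1O`, 66%

Compound 1 stands highest of the three. How its core differs from that of compound 3 is not broken down here. Between compound 3 and compound 2 the change is methyl in place of chloro on an aromatic carbon, and the step in this assay is a number 15 percentage points lower from compound 3 to compound 2 (beyond the scatter).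

Compound 4, `Cc1cc(CNC(C)(C)C)c(O)c(Nc2nc3cc(F)c(F)cc3n2Cc2ccc(C(F)(F)F)cc2)c1`, has not yet been measured. It differs from compound 1 by methyl in place of chloro on an aromatic carbon. This is the same kind of change as that from compound 3 to compound 2, though the place differs: meta to a ((tert-butyl)amino)methyl group rather than meta to a (ethylamino)methyl group.

The expected step is a number 14 percentage points lower from compound 1 to compound 4 (beyond the scatter), resting on compound 3 and compound 2 and their step of a number 15 percentage points lower from compound 3 to compound 2 (beyond the scatter). For compound 4 the estimate is 80%, between 62% and 93%.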

Compound 4, percent of the compound remaining in the Rattus norvegicus assay: 89%
Compound 4: the middle estimate sits 9 percentage points below what was measured; measured number inside the range.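

In the Rattus norvegicus assay the swap of methyl for chloro gives a number 5 percentage points lower from compound 1 to compound 4 (within the scatter), and the two steps now available do not differ: the same change on two cores in the Rattus norvegicus assay, a number 15 percentage points lower (beyond the scatter) from compound 3 to compound 2 and a number 5 percentage points lower (within the scatter) from compound 1 to compound 4, 10 percentage points apart, within the scatter of two such steps. The change therefore behaves alike on these two cores as far as this assay can tell, but two steps are too few to set a rule for the series. In a physicochemical assay for solubility, read by HPLC, measured as kinetic solubility, with a stated time of 24 h, at pH 6.5 (a lower number here means a less soluble compound, a higher number a more soluble compound), compound 1 gives < 5000 nM, which is a limit of the assay and not a number. In the physicochemical assay compound 4 gives < 5000 nM, which is likewise a limit of the assay and not a number. In the physicochemical assay the step cannot be read, since both values are limits of the assay and not numbers: the limit of < 5000 nM in the physicochemical assay, at which 2 of the 2 values shown sit.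

The compounds shown leave open how a fluoro or a methoxy group would fare at this place in the Rattus norvegicus assay. They also leave open how the swap reads in the physicochemical assay for compounds that give a number there.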